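Removing a Drawn Configuration from Compound 2

A few compounds are considered here, and "the series" means these few. Any claim that something is new, unique, unknown or untested is made for them only; others in the source may bear on it.

Three compounds share one core, and all have been tested in an ADME assay on Vero cells (Chlorocebus sabaeus) for cytotoxicity; a higher number here means that more compound is tolerated, a lower number that less compound is tolerated. Compound 1 has the structure `CON=C1CCC(CN2CCN(c3nc(=O)c4cc(C(F)(F)F)cc([N+](=O)[O-])c4s3)C[C@@H]2C)CC1`. In this assay compound 1 gives > 64 ug/mL, which is a limit of the assay rather than a number. Compound 2 has the structure `CON=C1CCC(CN2CCN(c3nc(=O)c4cc(C(F)(F)F)cc([N+](=O)[O-])c4s3)C[C@H]2C)CC1`. In this assay compound 2 gives > 64 ug/mL, again a limit. Compound 3 has the structure `CCON=C1CCC(CN2CCN(c3nc(=O)c4cc(C(F)(F)F)cc([N+](=O)[O-])c4s3)C[C@H]2C)CC1`. In this assay compound 3 gives > 64 ug/mL, also a limit. Two measured steps connect them: a step that the two limits leave unreadable from compound 1 to compound 2 and a step that the two limits leave unreadable from compound 2 to compound 3. Neither can be read because of the limit of > 64 ug/mL in this assay, at which 3 of the 3 values shown sit. Compound 2 thus stands at the limit, and the two other values stand there with it.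

Compound 4 has the structure `CON=C1CCC(CN2CCN(c3nc(=O)c4cc(C(F)(F)F)cc([N+](=O)[O-])c4s3)CC2C)CC1`. The difference from compound 2 is this: the two compounds have the same atoms and bonds; at least one stereo element is drawn with a configuration in one of them and without one in the other: 1 of 3 stereo elements differ; a stereocentre at a saturated ring carbon is drawn R in compound 2 and without a configuration in compound 4. Among the compounds with values here, no measured step gives a readable size for such a change; the pair of compounds 1 and 2 shows only (the fact that one of compounds 1 and 2 is drawn with a defined configuration and the other without, at the place where they differ). With every measured value sitting at the limit, no step beyond the scatter is expected, and the estimated step that the limit leaves unreadable from compound 2 to compound 4 is therefore expected to be close to none. Compound 4 is expected to give about 80 ug/mL, within a range from 45 ug/mL to 160 ug/mL, most probably reported again as a limit.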

Compound 4, half-maximal cytotoxic concentration: > 64 ug/mL
Compound 4 ended at the assay's limit; the forecaster's own chance of this, stated with the estimate: 85%; the middle value is on the limit's open side.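

In this assay compound 4 gives > 64 ug/mL, which is a limit of the assay and not a number. The steps from compound 1 and compound 2 to compound 4 therefore cannot be read: the limit of > 64 ug/mL in this assay, at which 4 of the 4 values shown sit.

The compounds shown leave open whether the configuration drawn at the saturated ring carbon makes any difference in this assay.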